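Difluorophenyl thiosemicarbazones: cytotoxicity at the assay limit

This account rests on a few compounds, and the source may have more. Where it says the series, first, only, none or still open, it means among the compounds named here.

Compound 1 `Fc1cc(F)cc(/C=N/NC(=S)Nc2cccc3ccccc23)c1` gives > 500 ug/mL in an ADME assay on NIH3T3 cells (Mus musculus) for cytotoxicity, read by XTT assay, with a stated time of 24 h (a higher number here means a weaker inhibitor, a lower number a stronger inhibitor), a limit of the assay rather than a number. Compound 2 `Fc1cc(F)c(/C=N/NC(=S)Nc2cccc3ccccc23)c(F)c1` gives > 500 ug/mL in this assay, likewise a limit. Compound 3 `Fc1ccc(/C=N/NC(=S)Nc2cccc3ccccc23)cc1F` gives > 500 ug/mL in this assay, again a limit. The step that the two limits leave unreadable from compound 1 to compound 3 is therefore unreadable. Compound 4 `Fc1ccc(F)c(/C=N/NC(=S)Nc2cccc3ccccc23)c1` differs from compound 1 by 2,5-difluorophenyl in place of 3,5-difluorophenyl on a carbon with a double bond to nitrogen. Going by the values given here, no measured step bears on this change with a readable size, and every value shown sits at the limit of > 500 ug/mL in this assay, at which 3 of the 3 values shown sit. A step beyond the scatter is therefore not expected from compound 1 to compound 4, though a reading at the limit cannot settle this. Compound 4 is expected to give 600 ug/mL, within 300 ug/mL to 2000 ug/mL, a step that the limit leaves unreadable from compound 1 to compound 4 that is expected to stay within scatter.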

Compound 4, half-maximal inhibitory concentration: > 500 ug/mL
Compound 4: no number, only a limit (the forecaster's own chance of this, stated with the estimate: 85%); the middle value is on the limit's open side.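

Compound 4 gives > 500 ug/mL in this assay, a limit and not a number, so no step from compound 1 or compound 3 to compound 4 can be read: the limit of > 500 ug/mL in this assay, at which 4 of the 4 values shown sit.

Going by these compounds, whether 2,5-difluorophenyl, 3,4-difluorophenyl and 3,5-difluorophenyl differ at all in this assay remains open.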